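This account rests on a few compounds, and the source may have more. Where it says the series, first, only, none or still open, it means among the compounds named here.

Compound 3 `COc1ccc(-n2nc(-c3ccccc3)nc2CNc2ccc(C(=O)NO)cc2)cc1` gives 63.4% in an assay on Sf9 cells for inhibition of protein deacetylase HDAC6 (Homo sapiens), read by fluorescence, with a stated time of 40 min, tested at 100 nM; a higher number here means more inhibition at the concentration tested (going by the name of the read-out), a lower number less inhibition. That is the highest of the three numbers measured, but only in a narrow sense: compound 1 `Cc1ccc(-c2nc(CNc3ccc(C(=O)NO)cc3)n(-c3ccccc3)n2)cc1` gives 62.2% and compound 2 `O=C(NO)c1ccc(NCc2nc(-c3ccc(Br)cc3)nn2-c2ccccc2)cc1` gives 54.7% in this assay, and both gaps to compound 3 lie within the scatter of repeated measurements. For the measured compounds named here, the single step between measured compounds, bromo in place of methyl on an aromatic carbon, moves the number a number 7.5 percentage points lower from compound 1 to compound 2 (within the scatter), again within the scatter.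

Compound 4 `Cc1cc(C)cc(-n2nc(-c3ccccc3)nc2CNc2ccc(C(=O)NO)cc2)c1` differs from compound 3 in one place: 3,5-dimethylphenyl in place of 4-methoxyphenyl on an aromatic nitrogen. Going by the values given here, no measured step touches this part of the shared core, so there is nothing that speaks directly for a change; the only measured step, at a different place, stayed within the scatter. On that basis the step from compound 3 to compound 4 is expected to be a number 3.4 percentage points lower from compound 3 to compound 4 (within the scatter), that is, nothing beyond the scatter. Compound 4 is therefore expected to give 60% in this assay, with a range from 45% to 75%.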

Compound 4, a percentage reported as inhibition, at one concentration (the size of the read-out at that concentration, not a potency): 49.8%
The estimate for compound 4 lay 10.2 percentage points above the measured number; the measured number falls inside the stated range.
By their numbers in this assay, from the lowest: compounds 4, 2, 1 and 3 (each within the scatter of the next, the first and the last beyond it).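

In this assay, for the compounds shown here, 3,5-dimethylphenyl in place of 4-methoxyphenyl on the aromatic nitrogen comes out as a number 13.6 percentage points lower from compound 3 to compound 4 (beyond the scatter), so this position can respond to a change of group, which no earlier step could show. The two groups have the same count of heavy atoms and each holds one six-membered aromatic ring of carbon only, but the entering group has no oxygen and no hydrogen-bond acceptor, so the counted differences lie there. Nothing measured here explains the drop.

As far as these compounds go, this single swap removes the methoxy group and adds two methyl groups at once, so it remains open which of these matters, or whether both do. From the compounds shown here alone, it also remains open how a 4-hydroxyphenyl or a 4-aminophenyl group on this nitrogen would read out in this assay.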